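This account rests on a few compounds, and the source may have more. Where it says the series, first, only, none or still open, it means among the compounds named here.

Of the compounds shown here, three with one shared core have been measured in a physicochemical assay for solubility, read by chemiluminescence, in phosphate buffer, measured as kinetic solubility, at pH 7.4 (on this read-out higher numbers stand for higher solubility and lower numbers for lower solubility), and they differ only in the group on an aromatic carbon of a six-membered aromatic ring of carbon only. Compound 1 `O=C(NCC1(c2nc(-c3ccccc3)cs2)CCOCC1)c1ccc(-n2cncn2)cc1` gives 191000 nM, compound 2 `Cc1cc(C)n(-c2ccc(C(=O)NCC3(c4nc(-c5ccccc5)cs4)CCOCC3)cc2)n1` gives 33000 nM, and compound 3 `Cn1ccc(Nc2ccc(C(=O)NCC3(c4nc(-c5ccccc5)cs4)CCOCC3)cc2)n1` gives 48000 nM. Compound 3 cannot be separated from its nearest neighbour, as a 1.5-fold higher number from compound 2 to compound 3 (0.16 log units; within the scatter) shows. Its gap to the top of the set is real: a 4.0-fold lower number from compound 1 to compound 3 (0.60 log units; beyond the scatter), and similarly a 5.8-fold lower number from compound 1 to compound 2 (0.76 log units; beyond the scatter).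

Compound 4 `O=C(NCC1(c2nc(-c3ccccc3)cs2)CCOCC1)c1ccc(CN2CCCCC2)cc1` changes the same place, with (piperidin-1-yl)methyl in place of (1-methyl-1H-pyrazol-3-yl)amino on an aromatic carbon. Going by the values given here, no measured compound carries a non-aromatic ring at this place, so the three steps offer only a rough guide to size and little guide to direction. Among these three compounds, changes here have produced modest steps or none beyond the scatter. Compound 1, at 191000 nM, shows how high the number has reached with a different group here, and that leaves room for a rise. A modest rise in this assay is therefore expected, tentatively, as a 2.3-fold higher number from compound 3 to compound 4 (0.36 log units; beyond the scatter). For compound 4 the estimated value is 110000 nM, with an expected range from 40000 nM to 220000 nM.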

Compound 4, solubility: >= 396000 nM
Compound 4: only a limit was reported; the forecaster's own chance of this, stated with the estimate: 5%; middle value at least 3.6-fold (0.55 log units) away from the limit.
By their numbers in this assay, from the lowest: compounds 2 and 3 (each within the scatter of the next); then compound 1. At a limit, above all of these: compound 4.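

Compound 4 gives no exact number in this assay, only a limit: the limit of >= 396000 nM in this assay, at which 1 of the 4 values shown sits.

Going by these compounds alone, until now, the aromatic-ring groups at this position had produced only modest steps or none beyond the scatter, whereas (piperidin-1-yl)methyl, the first group here with a six-membered non-aromatic ring, gives an at least 8.2-fold higher number from compound 3 to compound 4 (0.91 log units; beyond the scatter) and an at least 12-fold higher number from compound 2 to compound 4 (1.07 log units; beyond the scatter), the second being a large step. It also passes the earlier top of the set, with an at least 2.0-fold higher number from compound 1 to compound 4 (0.31 log units; beyond the scatter), so this place on the aromatic ring allows a wider span of numbers than the first three compounds revealed, and with 7 heavy atoms in both the leaving and the entering group, heavy-atom count does not track the step from compound 3.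

The compounds shown leave open which part of (piperidin-1-yl)methyl goes with this result: the ring nitrogen, the non-aromatic ring or the link to the aromatic ring. On these data alone, a cyclohexylmethyl group, with carbon in place of that nitrogen, and a morpholin-4-ylmethyl group would help separate these parts, while the full size of each new step remains unknown.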